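Swapping the Aryl Group on an Aromatic Nitrogen

The source may report more compounds than this note shows. Statements on the series, on what has been measured and on what is new or still open speak of the compounds shown alone.

In a functional assay on MKN-45 cells (Homo sapiens) for inhibition, read by CCK-8 assay, with a stated time of 24 h (on this read-out lower numbers stand for stronger inhibition and higher numbers for weaker inhibition), compound 1 (`N#Cc1ccccc1-n1cc(-c2ccc(/C=C3\C(=O)Nc4ccccc43)cc2)nn1`) gives 14600 nM and compound 3 (`O=C1Nc2ccc(F)cc2/C1=C/c1ccc(-c2cn(-c3ccccc3F)nn2)cc1`) gives 8510 nM so that these two values lie within the usual scatter of each other. Compound 2 (`N#Cc1ccc(-n2cc(-c3ccc(C=C4C(=O)Nc5ccccc54)cc3)nn2)cc1`) returns > 20000 nM as a limit and not a number. Compound 3 therefore stands level with compound 1 as one of only two numeric results.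

Compound 4 (`O=C1Nc2ccc(F)cc2/C1=C/c1ccc(-c2cn(-c3ccc(Cl)c(C(F)(F)F)c3)nn2)cc1`) carries 4-chloro-3-(trifluoromethyl)phenyl in place of 2-fluorophenyl on an aromatic nitrogen. Within the data shown here, no measured pair isolates a change at this place, so the expectation rests on compound 3 with its 8510 nM as the starting point. In this assay no step beyond the scatter is expected, with only a slight lean towards a lower number. The estimated step of a 1.4-fold lower number from compound 3 to compound 4 (0.15 log units; within the scatter) is accordingly small and uncertain in sign. The expected value for compound 4 is 6000 nM within an estimated range of 1800 nM to 20000 nM for this measurement.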

Compound 4, half-maximal inhibitory concentration: > 20000 nM
Compound 4: no number, only a limit; the forecaster's own chance of this, stated with the estimate: 15%; middle value at least 3.3-fold (0.52 log units) away from the limit.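

In this assay, among these compounds, replacing 2-fluorophenyl with 4-chloro-3-(trifluoromethyl)phenyl on the aromatic nitrogen gives the first step that can be read at this position, an at least 2.3-fold higher number from compound 3 to compound 4 (0.37 log units; beyond the scatter). The position is therefore not indifferent to the aryl group it carries, at least for this change on the core of compound 3. Compound 4 has a limit and not a number, so the full size of the step cannot be read: the limit of > 20000 nM in this assay, at which 2 of the 4 values shown sit.

On these data alone, the chlorine and the trifluoromethyl enter together as one change, and the share of each in this step remains open. Also open, as far as these compounds go, is how a phenyl group bearing an amine or a carboxylic acid would read at this position in this assay.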